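The compounds below may be only part of what the source reports. "The series", "measured", "known", "first", "only" and "open" are said of these compounds alone.

Of the compounds shown here, three built on one shared core have been measured. Compound 1 `COc1cc(/C=C/C(=O)C2=C(/C=C/c3ccc(O)c(OC)c3)NC(=O)NC2c2ccccc2O)ccc1O` gives 29.9% in a functional assay, with a stated time of 20 min, tested at 2 uM; a lower number here means a weaker effect, a higher number a stronger effect of the compound at the concentration tested. Compound 2 `COc1cc(/C=C/C(=O)C2=C(/C=C/c3ccc(O)c(OC)c3)NC(=O)NC2c2ccc(O)cc2)ccc1O` gives 33.3% in this assay, and compound 3 `COc1cc(/C=C/C(=O)C2=C(/C=C/c3ccc(O)c(OC)c3)NC(=O)NC2c2ccc(N(C)C)cc2)ccc1O` gives 28.2%. Compound 3 stands within the scatter of both companions: the step of a number 1.7 percentage points lower from compound 1 to compound 3 (within the scatter) and the step of a number 5.1 percentage points lower from compound 2 to compound 3 (within the scatter) are each too small to count as a change, just as the step of a number 3.4 percentage points higher from compound 1 to compound 2 (within the scatter) is. The three numbers therefore describe one level of activity, not a ranking.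

Compound 4 `COc1cc(/C=C/C(=O)C2=C(/C=C/c3ccc(O)c(OC)c3)NC(=O)NC2c2cccc([N+](=O)[O-])c2)ccc1O` differs from compound 3 at the same place that varies across the first three compounds: 3-nitrophenyl in place of 4-(dimethylamino)phenyl on a saturated ring carbon. Going by the values given here, the steps that bear on this change are those that swapped the group on that saturated ring carbon, namely a number 1.7 percentage points lower from compound 1 to compound 3 (within the scatter) and a number 5.1 percentage points lower from compound 2 to compound 3 (within the scatter), together with a number 3.4 percentage points higher from compound 1 to compound 2 (within the scatter); all of them stayed within the scatter, although none of them brought in a 3-nitrophenyl group. On that basis he expects no step beyond the scatter in this assay, so that a number 1.8 percentage points higher from compound 3 to compound 4 (within the scatter) is the estimated move. For compound 4 the estimate is accordingly 30%, with a likely range from 18% to 42%.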

Compound 4, a percentage reported as activity, at one concentration (the size of the read-out at that concentration, not a potency): 10.2%
Beside the measured number, compound 4's estimate is 19.8 percentage points above it; measured number below the stated range.
By their numbers in this assay, from the lowest: compound 4; then compounds 3, 1 and 2 (each within the scatter of the next).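

In this assay, the saturated ring carbon of the shared core turns out not to be indifferent to the aryl group it carries: introducing 3-nitrophenyl gives a number 18 percentage points lower from compound 3 to compound 4 (beyond the scatter), a number 23.1 percentage points lower from compound 2 to compound 4 (beyond the scatter) and a number 19.7 percentage points lower from compound 1 to compound 4 (beyond the scatter). Going by these compounds alone, the 2-hydroxyphenyl, 4-hydroxyphenyl and 4-(dimethylamino)phenyl groups had left the read-out at one level, so compound 4 provides the first change beyond the scatter at this carbon and, with all three of its steps beyond the scatter, is the weakest of the four compounds at the concentration tested. Nothing shown here gives a reason for this loss of effect.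

The compounds shown leave open whether the lower number goes with the nitro group itself or with its place in 3-nitrophenyl, and a 4-nitrophenyl group would bear directly on that question, as would a 3-aminophenyl or 3-methoxyphenyl group for the nitro group. Also open, on these data alone, is how an unsubstituted phenyl group or a 3-carboxyphenyl group would stand against these four compounds, and since each read-out comes from a single concentration, none of these numbers gives a potency.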